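The source may hold more compounds than are shown below. What is called first, only, known or untested is meant among the compounds shown, and "the series" means these compounds.

Working notes on the series. In a functional assay on A549 cells (Homo sapiens) for antiproliferative activity, read by MTT assay, with a stated time of 72 h (on this read-out higher numbers stand for weaker inhibition and lower numbers for stronger inhibition), compound 1 `Cc1nc(C)c(/C=C/C(=O)/C=C/c2cccc(O)c2)nc1C` gives 4300 nM, and compound 2 `COc1cc(/C=C/C(=O)/C=C/c2nc(C)c(C)nc2C)cc(OC)c1OC` gives 1600 nM. Compound 1 therefore holds the higher of the two numbers, meaning the weaker inhibition, and its gap to compound 2 lies beyond the usual scatter. These two compounds differ in more than one place, so their gap does not isolate any single change.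

The next compound is compound 3 `Cc1nc(C)c(/C=C/C(=O)/C=C/c2ccccc2)nc1C`, not yet measured in this assay. Compared with compound 1, the change is hydrogen in place of hydroxy on an aromatic carbon, turning 3-hydroxyphenyl into phenyl. For the measured compounds named here, no measured pair shows this change alone, so the expectation has only a weak basis. With compound 2 at 1600 nM and compound 1 at 4300 nM, the two measured numbers span a narrow range. A small step within the scatter, with no firm direction, is expected, and the estimated step is a 1.2-fold lower number from compound 1 to compound 3 (0.09 log units; within the scatter). For compound 3 the expected value is 3500 nM, with an estimated range of 1300 nM to 9500 nM.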

Compound 3, half-maximal inhibitory concentration: 12300 nM
Compound 3: the middle estimate sits 3.5-fold (0.55 log units) below what was measured; measured number above the stated range.
By their numbers in this assay, from the lowest: compound 2; then compound 1; then compound 3.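

For the compounds shown here, the step from 3-hydroxyphenyl to phenyl, hydrogen in place of hydroxy on an aromatic carbon, gives a 2.9-fold higher number from compound 1 to compound 3 (0.46 log units; beyond the scatter) in this assay, and it is the only change so far seen on its own. It shows that the hydroxy group on this carbon is not a silent feature of compound 1: without it, inhibition is weaker, by a modest step that lies beyond the scatter. This reading rests on the single pair of compound 1 and compound 3, and no measurement shown here accounts for why the hydroxy group matters.

Going by these compounds, it remains open whether the gain belongs to hydroxy itself or would also appear with a methoxy group, an amine or a fluorine on the same carbon. Also unresolved is whether the same step would hold on the ring of compound 2, or in a compound carrying a carboxylic acid at this place.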